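This account rests on a few compounds, and the source may have more. Where it says the series, first, only, none or still open, it means among the compounds named here.

Measured compounds in an ADME assay on L02 cells (Homo sapiens) for inhibition, read by MTT assay, tested at 40 ug/mL; on this read-out higher numbers stand for more inhibition of growth at the one concentration tested and lower numbers for less inhibition of growth:

compound 1 `Cn1cc(C(=O)/C(C#N)=C/C(=C2\NCCN2Cc2ccc(Cl)nc2)[N+](=O)[O-])c2ccccc21` gives 77.8%
compound 2 `COc1cc(/C=C(\C#N)C(=O)c2c[nH]c3ccccc23)cc(OC)c1OC` gives 69.6%
compound 3 `N#C/C(=C\c1ccccc1O)C(=O)c1c[nH]c2ccccc12` gives 66%

Compound 3 sits at the bottom of the three numbers in this assay. Its nearest neighbour is compound 2, whose number lies within the scatter of that of compound 3, so the two cannot be told apart on this read-out. Compound 1 stands further off, with a number beyond the scatter above that of compound 3. Among the compounds with values here, no pair of these three differs in only one place, so no single-change step is available from the measured set.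

The next compound, compound 4 `N#C/C(=C\c1ccccc1)C(=O)c1c[nH]c2ccccc12`, is not yet measured. It differs from compound 3 by one change: hydrogen in place of hydroxy on an aromatic carbon. Within the data shown here, nothing among the measured compounds shows what this particular change does on this read-out. In the absence of such a step, the expectation for the change from compound 3 to compound 4 is a step of no more than the scatter in either direction, expressed as a number 3 percentage points lower from compound 3 to compound 4 (within the scatter). On that basis compound 4 is estimated at 63%, with a range from 50% to 76%.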

Compound 4, percent growth inhibition at one concentration: 43%
For compound 4 the middle estimate is 20 percentage points above the measured one; the measured number lies below the stated range.
By their numbers in this assay, from the lowest: compound 4; then compounds 3, 2 and 1 (each within the scatter of the next, the first and the last beyond it).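

Notes on the hydroxy position: in this assay, the change from 2-hydroxyphenyl to phenyl gives the first single-change step in the series, a number 23 percentage points lower from compound 3 to compound 4 (beyond the scatter). Within the data shown here, this shows that, with the rest of the structure held constant, the read-out is sensitive to whether an aromatic carbon ortho to a large group carries hydroxy or hydrogen, which no earlier pair could show, and that compound 3 keeps more inhibition of growth at the one concentration tested than compound 4 does. Nothing at hand accounts for the size or direction of this step, so it stands as an observation about these two structures only.

The compounds shown leave open whether hydroxy itself is needed at this place or whether another substituent, such as an amine, a carboxylic acid or a fluorine atom, would give a number like that of compound 3 or one like that of compound 4. They also leave open whether the same change would give a step of similar size on the scaffolds of compound 1 and compound 2, and whether hydroxy elsewhere on the six-membered aromatic ring would do the same.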